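Working notes on four amide analogues, paw edema

The source may hold more compounds than are shown below. What is called first, only, known or untested is meant among the compounds shown, and "the series" means these compounds.

Values in a functional assay on the whole organism (strain albino) for inhibition, with Rattus norvegicus as the target, read by paw edema, with stated times of 30 min and 1 h, at a dose of 100 mg/kg by the oral route; a higher number here means more inhibition at the dose given (going by the name of the read-out), a lower number less inhibition:
compound 1 `COc1ccc(C2CC(c3ccc(OC)c(OC)c3)=NN2C(=O)C(C)Br)c(OC)c1`: 58%
compound 2 `COc1ccc(C2=NN(C(=O)C(C)Br)C(c3c(Cl)cccc3Cl)C2)cc1OC`: 51%
compound 3 `COc1ccc(C2CC(c3ccc(OC)c(OC)c3)=NN2C(=O)C(C)O[N+](=O)[O-])c(OC)c1`: 44%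

Compound 2 differs from compound 1 by 2,6-dichlorophenyl in place of 2,4-dimethoxyphenyl on a saturated ring carbon, and in this assay this gave a number 7 percentage points lower from compound 1 to compound 2 (within the scatter). Compound 3 differs from compound 1 by nitrooxy in place of bromo on a saturated chain carbon bound to a carbonyl carbon and a saturated chain carbon, which gave a number 14 percentage points lower from compound 1 to compound 3 (beyond the scatter); compound 3 stands lowest of the three, though against compound 2 the gap is within the scatter.

Compound 4 `COc1ccc(C2=NN(C(=O)C(C)O[N+](=O)[O-])C(c3c(Cl)cccc3Cl)C2)cc1OC` is not yet measured in this assay. It differs from compound 3 by 2,6-dichlorophenyl in place of 2,4-dimethoxyphenyl on a saturated ring carbon. This is the same kind of change as from compound 1 to compound 2, on a core that differs by nitrooxy in place of bromo on a saturated chain carbon bound to a carbonyl carbon and a saturated chain carbon; around the place, the ring atom next to the changed carbon bears a (1-bromoethyl)carbonyl group (5 heavy atoms) in the earlier pair and a group of 8 heavy atoms here.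

For compound 4 a step of about a number 6 percentage points lower from compound 3 to compound 4 (within the scatter) in this assay is expected, resting on the step of a number 7 percentage points lower from compound 1 to compound 2 (within the scatter) seen for the same kind of change. The estimate for compound 4 in this assay is 38%, expected between 26% and 50%.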

Compound 4, a percentage reported as inhibition, in the whole organism at one dose (the size of the read-out at that dose, not a potency): 47%
Estimate against measurement, compound 4: 9 percentage points below; the range from low to high includes it.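

In this assay, 2,6-dichlorophenyl in place of 2,4-dimethoxyphenyl on the nitrooxy core gives a number 3 percentage points higher from compound 3 to compound 4 (within the scatter), and this does not separate from the same change on the bromo core: the same change on two cores in this assay, a number 7 percentage points lower (within the scatter) from compound 1 to compound 2 and a number 3 percentage points higher (within the scatter) from compound 3 to compound 4, 10 percentage points apart, within the scatter of two such steps. Nitrooxy in place of bromo on the core bearing 2,6-dichlorophenyl gives a number 4 percentage points lower from compound 2 to compound 4 (within the scatter), and this also does not separate from the same change on the core bearing 2,4-dimethoxyphenyl: the same change on two cores in this assay, a number 14 percentage points lower (beyond the scatter) from compound 1 to compound 3 and a number 4 percentage points lower (within the scatter) from compound 2 to compound 4, 10 percentage points apart, within the scatter of two such steps. Both changes can therefore be carried between these two cores without a detectable dependence on the core, but with one pair of steps per change, this does not show that the steps are equal, nor does it fix the size or direction of the aryl step.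

The compounds shown leave open whether the same holds for other groups on the saturated ring carbon, such as an unsubstituted phenyl or a pyridine ring. Also open, as far as these compounds go, is how an amine or a carboxylic acid would read in place of bromo or nitrooxy on the chain carbon.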